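This account rests on a few compounds, and the source may have more. Where it says the series, first, only, none or still open, it means among the compounds named here.

Measured so far:
Compound 1, `C/C(=N/NC(=S)N(Cc1ccccc1)Cc1ccccc1)c1ccc(O)cc1`: 160000 nM in an ADME assay on Vero cells (Chlorocebus sabaeus) for cytotoxicity, read by MTT assay, with a stated time of 72 h; a higher number here means that more compound is tolerated, a lower number that less compound is tolerated
Compound 2, `C=CCN(CC=C)C(=S)N/N=C(/C)c1ccc(N)cc1`: "not determined" (no result reported) in this assay, so no result is reported

Going by the values given here, compound 1 is the only compound with a number in this assay; compound 2 was run in the same assay without a reported result, so compound 1 stands alone, and there is no measured step between two compounds to set a scale for the next change.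

Compound 3, `C/C(=N/NC(=S)N(Cc1ccccc1)Cc1ccccc1)c1ccc([N+](=O)[O-])cc1`, differs from compound 1 in one place: nitro in place of hydroxy on an aromatic carbon. Among the compounds with values here, with no measured step of this kind to lean on, the size of the change in this assay is uncertain. A small step is expected, tending toward less compound being tolerated, though one that could stay within the usual scatter. For compound 3 the expected value in this assay is 100000 nM, with a range from 30000 nM to 300000 nM. This estimate amounts to an expected step of a 1.6-fold lower number from compound 1 to compound 3 (0.20 log units; within the scatter).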

Compound 3, half-maximal cytotoxic concentration: < 150000 nM
Compound 3: a limit, no number (the forecaster's own chance of this, stated with the estimate: 20%); the middle value does not contradict the limit.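

Compound 3 gives the first reading of a change at this place, where 4-hydroxyphenyl becomes 4-nitrophenyl, but its result in this assay is a limit and not a number: the limit of < 150000 nM in this assay, at which 1 of the 3 values shown sits.

Read as a step, nitro in place of hydroxy on this aromatic carbon gives an at least 1.0-fold lower number from compound 1 to compound 3 (0.02 log units; that floor lies within the scatter). As far as these compounds go, the reading is therefore one-sided: it gives a floor for the step, while the true size of the step stays unknown and could be small or large.

The compounds shown leave open how a group such as methoxy or a carboxylic acid would read at this same place in this assay. They also leave open whether a number, rather than a limit, would place the nitro compound within the scatter of the hydroxy compound or beyond it.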